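Removing the bromo from compound 2: an expected value

This account rests on a few compounds, and the source may have more. Where it says the series, first, only, none or still open, it means among the compounds named here.

Measured compounds:
- compound 1, `COc1cc(CCc2cccc(Cl)c2Cl)cc(OC)c1O`: 11 nM
- compound 2, `COc1cc(CCc2ccc(Br)cc2)cc(OC)c1O`: 1490 nM
- compound 3, `COc1ccc(CCc2ccc([N+](=O)[O-])cc2)cc1OC`: 13700 nM

In a functional assay on MKN-45 cells (Homo sapiens) for antiproliferative activity, read by MTT assay, with a stated time of 72 h (a higher number here means a weaker inhibitor, a lower number a stronger inhibitor), compound 1 gives 11 nM, the lowest of the three numbers. Compound 2 gives 1490 nM, the second highest number; its nearest neighbour is compound 3 with 13700 nM, a higher number, while compound 1 stands far below it. No two of these compounds differ in a single place, so no step between measured compounds can be stated; the three values simply show that compound 1 is the strongest inhibitor of the group and compound 3 the weakest.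

Compound 4, `COc1cc(CCc2ccccc2)cc(OC)c1O`, has not yet been measured in this assay. It differs from compound 2 by hydrogen in place of bromo on an aromatic carbon. For the measured compounds named here, the only guidance comes from compound 1, whose value of 11 nM shows that a ring carrying halogens can give a strong inhibitor, and from compound 2 itself. On that basis the loss of the bromo is expected to move the number upward in this assay by a moderate step, a 2.7-fold higher number from compound 2 to compound 4 (0.43 log units; beyond the scatter), beyond the scatter but not by a large margin. Compound 4 is therefore estimated at 4000 nM, with a range from 1200 nM to 14000 nM.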

Compound 4, half-maximal inhibitory concentration: 1040 nM
Estimate against measurement, compound 4: 3.8-fold (0.59 log units) above, outside the stated range (below it).
By their numbers in this assay, from the lowest: compound 1; then compounds 4 and 2 (each within the scatter of the next); then compound 3.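

In this assay, putting hydrogen in place of bromo on an aromatic carbon of the six-membered ring, para to a large group, gives a 1.4-fold lower number from compound 2 to compound 4 (0.16 log units; within the scatter). For the compounds shown here, this is the first step that isolates a single place, and it shows that in this read-out the bromo at this position makes no difference that can be told from the usual scatter: the ring carrying no halogen at all and the ring carrying this one bromine stand level on the shared core. No independent measurement is available that could say why the exchange leaves the number where it is.

What the compounds shown leave open is whether this indifference belongs to the position or only to this pair of substituents, since an amine, a carboxylic acid or a longer chain at the same carbon could behave quite differently from either hydrogen or bromo. Compound 1 and compound 3 each differ from compound 4 in more than one place, so the steps that would separate their contributions cannot be read.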